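The source may hold more compounds than are shown below. What is called first, only, known or untested is meant among the compounds shown, and "the series" means these compounds.

For the measured compounds named here, compound 2 `O=C(Nc1c(C(O)(C(F)(F)F)C(F)(F)F)ccc2ccccc12)c1ccc(Cl)cc1` gives 570 nM in an assay on LtK cells with ATP-sensitive inward rectifier potassium channel 11 (Homo sapiens) as the target (on this read-out higher numbers stand for an effect only at larger amounts of compound and lower numbers for an effect already at smaller amounts), the highest of the two numbers measured so far; compound 1 `O=C(Nc1c(C(O)(C(F)(F)F)C(F)(F)F)ccc2ccccc12)c1cccc(Br)c1` gives 80 nM. Going by the values given here, the only measured step, a 7.1-fold higher number from compound 1 to compound 2 (0.85 log units; beyond the scatter), concerns an exchange between two halogenated phenyl groups and bears only loosely on the change to compound 3 `O=C(Nc1c(C(O)(C(F)(F)F)C(F)(F)F)ccc2ccccc12)c1cccs1`, which is thiophen-2-yl in place of 4-chlorophenyl on a carbonyl carbon. Among the compounds with values here, no measured step covers replacement of the aromatic ring itself, so no shift beyond the scatter is expected in either direction. The estimated step is a 1.4-fold lower number from compound 2 to compound 3 (0.15 log units; within the scatter). Compound 3 is therefore expected to give about 400 nM in this assay, within 100 nM to 1600 nM.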

Compound 3, half-maximal effective concentration: 12 nM
The estimate for compound 3 lay 33-fold (1.52 log units) above the measured number, outside the stated range (below it).
By their numbers in this assay, from the lowest: compound 3; then compound 1; then compound 2.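

On the carbonyl carbon, the aromatic ring itself proves to be a strong lever in this assay: thiophen-2-yl gives a 48-fold lower number from compound 2 to compound 3 (1.68 log units; beyond the scatter) and a 6.7-fold lower number from compound 1 to compound 3 (0.82 log units; beyond the scatter). Compound 3 thus has the lowest number of the three, so this position is not confined to halogenated phenyl groups. Nothing available explains this shift.

Still open, as far as these compounds go, is whether the shift follows the change of ring or the loss of the halogen, as the exchange alters both. Plain phenyl and furan-2-yl groups on this carbonyl carbon would separate the two.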